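This account rests on a few compounds, and the source may have more. Where it says the series, first, only, none or still open, it means among the compounds named here.

Measured so far in a functional assay on MCF7 cells (Homo sapiens) for antiproliferative activity, read by MTT assay, with a stated time of 24 h; a lower number here means a stronger inhibitor, a higher number a weaker inhibitor:
compound 2, `Fc1ccc(C2CC(c3ccc(Cl)cc3)=NN2c2ccc(-c3ccccc3)nn2)cc1`, gives 3750 nM
compound 1, `COc1ccc(C2CC(c3ccccc3)=NN2c2ccc(-c3ccccc3)nn2)cc1`, gives 100000 nM

Compound 2 stands lowest of the two numbers; the nearest is compound 1, whose number is higher by a margin well beyond the scatter. For the measured compounds named here, compound 1 and compound 2 differ in more than one place, so no single step is drawn between them; their two values show only that the changes together move the number far.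

Compound 3, `COc1ccc(C2CC(c3ccc(Cl)cc3)=NN2c2ccc(-c3ccccc3)nn2)cc1`, is not yet measured. It differs from compound 2 in one place: methoxy in place of fluoro on an aromatic carbon. Going by the values given here, the rest of compound 2 is unchanged, and the 4-methoxyphenyl is the one present in compound 1.

Among the compounds with values here, no step that isolates this change alone is available. A rise in this assay is expected, since compound 1 gives 100000 nM with the same 4-methoxyphenyl in place, though compound 3 keeps the remainder of compound 2. The step from compound 2 to compound 3 is estimated at a 4.0-fold higher number from compound 2 to compound 3 (0.60 log units; beyond the scatter). Compound 3 is therefore estimated at 15000 nM, with a range from 4000 nM to 80000 nM.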

Compound 3, half-maximal inhibitory concentration: 100000 nM
Compound 3: the middle estimate sits 6.7-fold (0.82 log units) below what was measured; the whole stated range lies below it.
By their numbers in this assay, from the lowest: compound 2; then compounds 1 and 3 (each within the scatter of the next).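

In this assay, the change from 4-fluorophenyl to 4-methoxyphenyl can now be read on its own, with the rest of the molecule held fixed, and it is a large step: a 27-fold higher number from compound 2 to compound 3 (1.43 log units; beyond the scatter) for methoxy in place of fluoro on an aromatic carbon. Where the 4-methoxyphenyl is present, chloro in place of hydrogen on an aromatic carbon leaves the number unmoved, with no change at the digits printed from compound 1 to compound 3 (within the scatter), so the chloro shows no effect in this setting, and its effect alongside the 4-fluorophenyl remains unread. For the compounds shown here, nothing available explains why this one exchange on the aromatic carbon moves the number so far.

The compounds shown do not tell whether the rise belongs to methoxy in particular or would follow other replacements of fluoro at this place, such as an amine, a hydroxyl, a plain hydrogen or a longer ether chain such as ethoxy. They also leave open how the 4-fluorophenyl compound behaves with hydrogen in place of the chloro, which would show whether the chloro contributes anything when fluoro is present.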